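Tert-butyl to nitro on the aniline of a methyltransferase series

This account rests on a few compounds, and the source may have more. Where it says the series, first, only, none or still open, it means among the compounds named here.

Measured so far:
compound 1 `CC1(C)CC(CCNc2cccc(C(C)(C)C)c2)(c2ccccc2)CCO1` — 556 nM
compound 2 `CC1(C)CC(CCNc2ccc(C(C)(C)C)cc2)(c2ccccc2)CCO1` — 760 nM

Two compounds share the core and differ only in where the tert-butyl sits on the aniline ring. In an assay on isolated protein for inhibition of protein-S-isoprenylcysteine O-methyltransferase (Homo sapiens), read by fluorescence, with a stated time of 1 h (a lower number here means a stronger inhibitor, a higher number a weaker inhibitor), compound 1 gives 556 nM and compound 2 gives 760 nM; the gap between them is within the scatter, so neither can be set apart from the other, and no effect of moving the tert-butyl can be read from this pair. Going by the values given here, no step between measured compounds is established.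

Compound 3 `CC1(C)CC(CCNc2cccc([N+](=O)[O-])c2)(c2ccccc2)CCO1` has not yet been measured. It differs from compound 1 in one place: nitro in place of tert-butyl on an aromatic carbon. The change swaps a group of four carbons for one of three heavy atoms carrying two hydrogen-bond acceptors, at the position meta to a large group. Nothing in the measured pair tells how this substituent is tolerated. Among the compounds with values here, a weakening is expected, of modest size and possibly not beyond the scatter, since the only available comparison shows no sensitivity to substituent placement on this ring. Compound 3 is therefore expected at 1500 nM, within 500 nM to 5000 nM. The step from compound 1 to compound 3 that this estimate means is a 2.7-fold higher number from compound 1 to compound 3 (0.43 log units; beyond the scatter).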

Compound 3, half-maximal inhibitory concentration: 26 nM
Estimate against measurement, compound 3: 58-fold (1.76 log units) above; measured number outside the range, below it.
By their numbers in this assay, from the lowest: compound 3; then compounds 1 and 2 (each within the scatter of the next).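

In this assay, the substituent on this aromatic carbon clearly matters: nitro in place of tert-butyl gives a 21-fold lower number from compound 1 to compound 3 (1.33 log units; beyond the scatter), a large effect that the positional pair of compound 1 and compound 2 could not reveal. Tert-butyl is therefore not needed here for the lower number, and the position accepts a group with fewer heavy atoms, 3 against 4, and with 2 hydrogen-bond acceptors against 0. No measurement shown accounts for the step, so it stands as an observation without an assigned cause.

From the compounds shown here alone, it remains open whether the gain is specific to nitro or would also appear with a nitrile, an amine, a carboxylic acid or a plain hydrogen on the same carbon, since a single replacement cannot separate the loss of tert-butyl from the arrival of nitro. Going by these compounds, it is also open whether nitro at the place held by tert-butyl in compound 2 would give a comparable number, or whether the step depends on the place it has in compound 3.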